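The source may report more compounds than this note shows. Statements on the series, on what has been measured and on what is new or still open speak of the compounds shown alone.

Working notes on the series. Compound 1 `COc1ccc(/C=C2\c3cc(OC)c(OC)c(OC)c3CC[C@@H]2O)cc1[N+](=O)[O-]` gives in a functional assay on SK-OV-3 cells (Homo sapiens) for inhibition, read by MTT assay (on this read-out lower numbers stand for stronger inhibition and higher numbers for weaker inhibition), a value of 4640 nM. Compound 2 `COc1ccc(/C=C2\c3cc(OC)c(OC)c(OC)c3CC[C@@H]2O)cc1C` differs from it by methyl in place of nitro on an aromatic carbon and in this assay compound 2 gives 730 nM, so a 6.4-fold lower number from compound 1 to compound 2 (0.80 log units; beyond the scatter). Compound 3 `COc1ccc(/C=C2\c3cc(OC)c(OC)c(OC)c3CC[C@H]2O)cc1[N+](=O)[O-]` shares the atoms and bonds of compound 1, the cores differing by the two compounds have the same atoms and bonds and differ only in configuration as drawn: 1 of 2 stereo elements differ; a stereocentre at a saturated ring carbon is drawn S in compound 1 and R in compound 3. For compound 3 in this assay only a limit is recorded, > 10000 nM. The step of an at least 2.1-fold higher number from compound 1 to compound 3 (0.33 log units; beyond the scatter) is therefore open-ended because of the limit of > 10000 nM in this assay, at which 1 of the 3 values shown sits, and the two compounds are set apart solely because of the fact that compounds 1 and 3 differ only in the configuration as drawn.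

Compound 4 `COc1ccc(/C=C2\c3cc(OC)c(OC)c(OC)c3CC[C@H]2O)cc1C` is not yet measured. It relates to compound 3 by methyl in place of nitro on an aromatic carbon, the same change as made from compound 1 to compound 2, at the same place. On that earlier step, a 6.4-fold lower number from compound 1 to compound 2 (0.80 log units; beyond the scatter), a fall of similar size is expected from compound 3, so compound 4 is expected to give about 2500 nM in this assay, the step of an at least 4.0-fold lower number from compound 3 to compound 4 (0.60 log units; beyond the scatter) being an estimate only, with a range from 900 nM to 10000 nM, since compound 3 sits at a limit and its true value is not known.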

Compound 4, half-maximal inhibitory concentration: 1340 nM
Compound 4: middle estimate off by 1.9-fold (0.27 log units), on the high side, and the stated range covers the measured number.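

In this assay methyl in place of nitro lowers the number on the core of compound 3 as well, an at least 7.4-fold lower number from compound 3 to compound 4 (0.87 log units; beyond the scatter), so the direction of the change carries across the two cores, while its size can be compared only loosely: the same change on two cores in this assay, a 6.4-fold lower number (0.80 log units; beyond the scatter) from compound 1 to compound 2 and an at least 7.4-fold lower number (0.87 log units; beyond the scatter) from compound 3 to compound 4; the limit leaves it open whether they differ. Compound 3 is recorded only as a limit, > 10000 nM, so the step on its core is open-ended and equal size on the two cores is not shown: the limit of > 10000 nM in this assay, at which 1 of the 4 values shown sits. With methyl in place, the step between the two configurations, a 1.8-fold higher number from compound 2 to compound 4 (0.26 log units; within the scatter), lies within the scatter, so these notes claim no effect of configuration for this pair: the fact that compounds 2 and 4 differ only in the configuration as drawn.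

Going by these compounds, only nitro and methyl appear at this aromatic carbon, so it remains open where an amine or a carboxylic acid there would fall. The two cores shown differ only at one stereocentre, so carrying the change to a core with a different substitution pattern also remains untested by these compounds.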